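The source may hold more compounds than are shown below. What is called first, only, known or untested is meant among the compounds shown, and "the series" means these compounds.

Of the compounds shown here, three share one core and have been measured so far. Compound 1 `CC1=C(C(=O)Nc2ccc(Br)cc2)C(c2ccc(Cl)cc2Cl)N=C(SCc2ccccc2)N1` is the starting point: in a functional assay on the whole organism (artery, strain albino) with Rattus norvegicus as the target, with a stated time of 600 min, at a dose of 10 mg/kg by the oral route (on this read-out higher numbers stand for more inhibition at the one dose given (going by the name of the read-out) and lower numbers for less inhibition), compound 1 gives 17.4%, the lowest of the three numbers shown. Compound 2 `CC1=C(C(=O)Nc2ccc(Br)cc2)C(c2ccc(Cl)cc2Cl)N=C(SCc2ccccc2Cl)N1` gives 24.6%, and compound 3 `CC1=C(C(=O)Nc2ccc(Br)cc2)C(c2ccc(Cl)cc2Cl)N=C(SCc2ccc(F)cc2)N1` gives 33.3%. Compound 4 `COc1ccc(C2N=C(SCc3ccccc3)NC(C)=C2C(=O)Nc2ccc(Br)cc2)cc1` has not yet been measured. It differs from compound 1 in one place: 4-methoxyphenyl in place of 2,4-dichlorophenyl on a saturated ring carbon. The measured steps all concern another part of the molecule, the aromatic ring of the benzylsulfanyl group: a number 7.2 percentage points higher from compound 1 to compound 2 (within the scatter), a number 15.9 percentage points higher from compound 1 to compound 3 (beyond the scatter) and a number 8.7 percentage points higher from compound 2 to compound 3 (within the scatter). None of them touches the saturated ring carbon, so they give no direction for this change. The step expected is therefore a number 0.6 percentage points higher from compound 1 to compound 4 (within the scatter), none beyond the scatter, with a wide range. Compound 4 is estimated to give 18%, between 4% and 36%.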

Compound 4, a percentage reported as inhibition, in the whole organism at one dose (the size of the read-out at that dose, not a potency): 11.3%
For compound 4 the middle estimate is 6.7 percentage points above the measured one; the measured number falls inside the stated range.
By their numbers in this assay, from the lowest: compounds 4, 1, 2 and 3 (each within the scatter of the next, the first and the last beyond it).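

In this assay, 4-methoxyphenyl in place of 2,4-dichlorophenyl on the saturated ring carbon gives a number 6.1 percentage points lower from compound 1 to compound 4 (within the scatter), so this first change at the position separates the two groups by no more than the usual scatter. Both chlorine atoms leave and an oxygen enters without a clear change in the read-out. No supporting measurement is available to explain this result. Still open, as far as these compounds go, is whether a plain phenyl, or a phenyl carrying an amine or a carboxylic acid, would step beyond the scatter here. Also open, from the compounds shown here alone, is how the 4-methoxyphenyl behaves alongside the fluorinated benzylsulfanyl group of compound 3.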